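This account rests on a few compounds, and the source may have more. Where it says the series, first, only, none or still open, it means among the compounds named here.

Compound 1 `O=C(c1ccccc1)c1ccn(-c2ccc3c(c2)B(O)OC3)c1`: > 10 ug/mL
Compound 2 `CCCCCC(=O)c1ccn(-c2ccc3c(c2)B(O)OC3)c1`: > 10 ug/mL

Both compounds were tested in an ADME assay on L929 cells (Mus musculus) for cytotoxicity, read by resazurin assay, with a stated time of 72 h; a higher number here means a weaker inhibitor, a lower number a stronger inhibitor. For compound 1 the value > 10 ug/mL is a limit of the assay, not a number. For compound 2 the value > 10 ug/mL is likewise a limit, so compound 2 stands only at the limit, with no number of its own. The step that the two limits leave unreadable from compound 1 to compound 2 therefore has no readable size, because both values sit at the limit of > 10 ug/mL in this assay, at which 2 of the 2 values shown sit.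

Compound 3 `Cc1ccsc1C(=O)c1ccn(-c2ccc3c(c2)B(O)OC3)c1` differs from compound 2 by 3-methylthiophen-2-yl in place of pentyl on a carbonyl carbon. For the measured compounds named here, the only measured step that bears on this change is a step that the two limits leave unreadable from compound 1 to compound 2, and it gives no size in either direction. Nothing here points to a shift beyond the scatter, and the expected step that the limit leaves unreadable from compound 2 to compound 3 is accordingly small. Compound 3 is expected at 20 ug/mL in this assay, with a range from 5 ug/mL to 80 ug/mL, most likely again reported only as a limit.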

Compound 3, half-maximal inhibitory concentration: > 10 ug/mL
Compound 3: no number, only a limit (the forecaster's own chance of this, stated with the estimate: 75%); the middle value does not contradict the limit.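

Compound 3 gives > 10 ug/mL in this assay, which is a limit and not a number. For the compounds shown here, no step among compound 1, compound 2 and compound 3 can be read: the limit of > 10 ug/mL in this assay, at which 3 of the 3 values shown sit. The compounds shown leave open whether phenyl, pentyl and 3-methylthiophen-2-yl on the carbonyl carbon differ at all in this assay.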